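Swapping the Sulfonyl Aryl Group: An Estimate for Compound 3

The compounds below may be only part of what the source reports. "The series", "measured", "known", "first", "only" and "open" are said of these compounds alone.

Measured compounds:
Compound 1 `CC1CCN(c2c(S(=O)(=O)c3ccc(F)cc3)cnc3ccc(Cl)cc23)CC1` gives 89% in an assay on isolated protein for displacement of a labelled ligand from metabotropic glutamate receptor 5 (Homo sapiens), with a stated time of 60 min, tested at 1 uM; on this read-out higher numbers stand for more inhibition at the one concentration tested (going by the name of the read-out) and lower numbers for less inhibition
Compound 2 `COc1ccc(S(=O)(=O)c2cnc3ccc(Cl)cc3c2N2CCC(C)CC2)cc1OC` gives 61% in this assay

Among the compounds with values here, compound 2 stands lowest of the two numbers measured so far; its nearest neighbour is compound 1, and the only measured step is a number 28 percentage points lower from compound 1 to compound 2 (beyond the scatter). Within the data shown here, that step replaced a 4-fluorophenyl group on the sulfonyl sulfur with a 3,4-dimethoxyphenyl group, so this one position is the only place where any change has so far been observed.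

Compound 3 `Cc1ccc(S(=O)(=O)c2cnc3ccc(Cl)cc3c2N2CCC(C)CC2)cc1` has not yet been measured. Compared with compound 2 the difference is 4-methylphenyl in place of 3,4-dimethoxyphenyl on a sulfonyl sulfur. Because the step of a number 28 percentage points lower from compound 1 to compound 2 (beyond the scatter) was brought about by putting the 3,4-dimethoxyphenyl group in, taking that group out again and replacing it with another single-ring aryl group is expected to move the number back upward, though the new 4-methylphenyl group is not the 4-fluorophenyl of compound 1, so the recovery may be partial. The expected step is therefore a number 19 percentage points higher from compound 2 to compound 3 (beyond the scatter). For compound 3 the estimate in this assay is 80%, with a range from 60% to 95%.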

Compound 3, a percentage reported as inhibition, at one concentration (the size of the read-out at that concentration, not a potency): 95%
Beside the measured number, compound 3's estimate is 15 percentage points below it; measured number inside the range.
By their numbers in this assay, from the lowest: compound 2; then compounds 1 and 3 (each within the scatter of the next).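

Compound 2's low number turns out not to be a general result of changing the aryl group on this sulfonyl sulfur. In this assay, 4-methylphenyl in place of 3,4-dimethoxyphenyl gives a number 34 percentage points higher from compound 2 to compound 3 (beyond the scatter) and is the largest step seen so far, so the choice of aryl group at this one place can move the read-out far in either direction. Methyl in place of fluoro on an aromatic carbon gives a number 6 percentage points higher from compound 1 to compound 3 (within the scatter) and so cannot be told apart from no change in this assay, which leaves 3,4-dimethoxyphenyl as the only group here tied to a clear loss, though nothing shown explains that loss.

From the compounds shown here alone, whether that loss comes from one of the two methoxy groups or needs both stays open, as does the outcome with a different kind of group on that aromatic carbon, such as an amine, a carboxylic acid or a longer chain. The rest of the molecule is the same in all three compounds, so it is also unknown whether these differences would hold if another part were changed.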